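This account rests on a few compounds, and the source may have more. Where it says the series, first, only, none or still open, it means among the compounds named here.

Three measured compounds share one core and differ only in the aryl groups hung on it. Compound 1 `COc1ccc(-c2nc(CNc3ccc(C(=O)NO)cc3)n(-c3ccccc3)n2)cc1` in an assay on Sf9 cells for inhibition of protein deacetylase HDAC6 (Homo sapiens), read by fluorescence, with a stated time of 40 min (a higher number here means a weaker inhibitor, a lower number a stronger inhibitor), gives 163 nM. Among the compounds with values here, compound 3 `O=C(NO)c1ccc(NCc2nc(-c3ccc(Cl)cc3)nn2-c2ccccc2)cc1` gives 181 nM, and the single one-place step in the measured set, a 1.1-fold higher number from compound 1 to compound 3 (0.05 log units; within the scatter), is a chloro in place of methoxy on an aromatic carbon. Compound 2 `Cc1ccc(-n2nc(-c3ccccc3)nc2CNc2ccc(C(=O)NO)cc2)cc1` gives 310 nM; its number lies nearest that of compound 3 and furthest from that of compound 1, yet both gaps stay within the scatter, so these three values do not separate the compounds.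

Compound 4 `O=C(NO)c1ccc(NCc2nc(-c3ccccc3)nn2-c2cccc(Cl)c2)cc1` has not yet been measured. It differs from compound 2 by 3-chlorophenyl in place of 4-methylphenyl on an aromatic nitrogen, a 3-chlorophenyl in place of 4-methylphenyl on an aromatic nitrogen of the shared core. Within the data shown here, no measured step touches this aromatic nitrogen. Among the measured compounds shown here, the only step available, a 1.1-fold higher number from compound 1 to compound 3 (0.05 log units; within the scatter), concerns a different position and stays within the scatter, which gives only weak support for the guess that swapping a chlorine for a methyl on an aryl ring changes little here. The step of a 1.2-fold lower number from compound 2 to compound 4 (0.08 log units; within the scatter) is therefore expected to be small, with no clear direction beyond the scatter. Compound 4 is estimated at 260 nM, with a range from 110 nM to 600 nM.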

Compound 4, half-maximal inhibitory concentration: 678 nM
Estimate against measurement, compound 4: 2.6-fold (0.42 log units) below, and the stated range ends below it.
By their numbers in this assay, from the lowest: compounds 1, 3 and 2 (each within the scatter of the next); then compound 4.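

In this assay, the aryl group on the aromatic nitrogen turns out to be able to shift the number, and the shift is toward a weaker inhibitor (a 2.2-fold higher number from compound 2 to compound 4 (0.34 log units; beyond the scatter)). Within the data shown here, the step is modest, but it is the first one-place step in this set to pass beyond the scatter; the only earlier one (a 1.1-fold higher number from compound 1 to compound 3 (0.05 log units; within the scatter)) lay on the aryl group at another position of the shared core and stayed within it. The counts do not track this change, since 4-methylphenyl and 3-chlorophenyl both have 7 heavy atoms, no hydrogen-bond donors or acceptors and no net charge, and nothing measured here offers an explanation for the step.

This single step swaps the methyl for a chlorine and also changes the group's name from a 4-substituted to a 3-substituted phenyl, so the two changes cannot be told apart; 3-methylphenyl on the same nitrogen would begin to separate them. The compounds shown also leave open how an aryl ring carrying an amine or a carboxylic acid would behave at this position.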